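The source may hold more compounds than are shown below. What is called first, only, known or untested is meant among the compounds shown, and "the series" means these compounds.

Measured in a functional assay on CCRF-CEM cells (Homo sapiens) for cytotoxicity, in the absence of a further agent; on this read-out higher numbers stand for weaker inhibition and lower numbers for stronger inhibition:
Compound 1 `Nc1nc(N)c(CCCNc2cc(F)ccc2[N+](=O)[O-])c(O)n1`: > 100000 nM, which is a limit of the assay and not a number.
Compound 2 `Nc1nc(N)c(CCCNc2cc(F)c([N+](=O)[O-])cc2[N+](=O)[O-])c(O)n1`: 1000 nM.

Among the measured compounds shown here, compound 2 gives the only true number so far, 1000 nM. Compound 3 `Nc1nc(N)c(CCCNc2cc(F)c(F)cc2[N+](=O)[O-])c(O)n1` differs from it in one place: fluoro in place of nitro on an aromatic carbon. For the measured compounds named here, one measured step bears on this, the large at least 100-fold lower number from compound 1 to compound 2 (2.00 log units; beyond the scatter), in which that same nitro replaced hydrogen. Losing this nitro should therefore give a large move to a higher number in this assay, although fluoro rather than hydrogen takes its place. The estimated change is a 20-fold higher number from compound 2 to compound 3 (1.30 log units; beyond the scatter). For compound 3 the expected value is 20000 nM, with an estimated range from 3000 nM to 100000 nM.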

Compound 3, half-maximal inhibitory concentration: 97000 nM
For compound 3 the middle estimate is 4.9-fold (0.69 log units) below the measured one; the measured number falls inside the stated range.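

In this assay, fluoro in place of nitro gives a 97-fold higher number from compound 2 to compound 3 (1.99 log units; beyond the scatter), so the lower number of compound 2 depends on the nitro itself and not on just any group other than hydrogen at this position. Fluoro in place of hydrogen gives an at least 1.0-fold lower number from compound 1 to compound 3 (0.01 log units; that floor lies within the scatter), so no gain from fluoro can be read here. Compound 1 gives > 100000 nM, which is a limit of the assay and not a number.

The compounds shown leave open whether a nitrile or an amine at this position would give a number nearer that of compound 2 or that of compound 3.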